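A few compounds are considered here, and "the series" means these few. Any claim that something is new, unique, unknown or untested is made for them only; others in the source may bear on it.

Of the compounds shown here, three built on one shared core have been tested so far. In a functional assay on U-87MG ATCC cells (Homo sapiens) for inhibition, read by MTT assay, with a stated time of 72 h (on this read-out higher numbers stand for weaker inhibition and lower numbers for stronger inhibition), compound 1 `COc1cc2c(Oc3ccc(NC(=O)c4nn(-c5ccccc5C)c(=O)cc4C)cc3F)ccnc2cc1OCCCN1CCCCC1` gives 2500 nM as its result. In the same this assay compound 2 `COc1cc2c(Oc3ccc(NC(=O)c4nn(-c5ccccc5OC(F)(F)F)c(=O)cc4C)cc3F)ccnc2cc1OCCCN1CCCCC1` gives 1300 nM as its result, and compound 3 `COc1cc2c(Oc3ccc(NC(=O)c4nn(-c5cccc(F)c5)c(=O)cc4C)cc3F)ccnc2cc1OCCCN1CCCCC1` gives 1500 nM as its result. Among these three numbers compound 3 stands second highest; its nearest neighbour is compound 2 and its furthest is compound 1, and both of those gaps lie within the scatter of the method.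

Compound 4 `COc1cc2c(Oc3ccc(NC(=O)c4nn(-c5ccc(Cl)cc5Cl)c(=O)cc4C)cc3F)ccnc2cc1OCCCN1CCCCC1` has not yet been measured. It differs from compound 3 by 2,4-dichlorophenyl in place of 3-fluorophenyl on an aromatic nitrogen only. Two measured steps change the ring on that same aromatic nitrogen: a 1.7-fold lower number from compound 1 to compound 3 (0.22 log units; within the scatter) and a 1.2-fold higher number from compound 2 to compound 3 (0.06 log units; within the scatter) both lie within the scatter. On that record no movement beyond the scatter in this assay is expected from this exchange. The step expected is no change at the digits printed from compound 3 to compound 4 (within the scatter) in size. Compound 4 is therefore estimated at 1500 nM with a likely range from 600 nM to 4000 nM in this assay.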

Compound 4, half-maximal inhibitory concentration: 1800 nM
The estimate for compound 4 lay 1.2-fold (0.08 log units) below the measured number, within the range that was stated.
By their numbers in this assay, from the lowest: compounds 2, 3, 4 and 1 (each within the scatter of the next).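

Compound 4 brings two chlorine atoms onto the ring on this aromatic nitrogen, a heavier change than any earlier exchange at this position, yet in this assay it stays within the scatter of all three earlier compounds (a 1.2-fold higher number from compound 3 to compound 4 (0.08 log units; within the scatter); a 1.4-fold higher number from compound 2 to compound 4 (0.14 log units; within the scatter); a 1.4-fold lower number from compound 1 to compound 4 (0.14 log units; within the scatter)). So far, then, four differently substituted phenyl rings at this position cannot be told apart in this cell assay, whether they carry one group or two, and whether that group is methyl, trifluoromethoxy, fluorine or chlorine. Nothing measured here offers a reason for this sameness.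

All four compounds keep a phenyl ring carrying only these small groups on that nitrogen. On these data alone, whether an amine or a carboxylic acid on that ring, or a plain alkyl chain replacing it, would move the number beyond the scatter remains open.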